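Trifluoromethyl in place of chloro: cytotoxicity on HeLa cells

The compounds below may be only part of what the source reports. "The series", "measured", "known", "first", "only" and "open" are said of these compounds alone.

Compound 1 `COc1nc(-c2ccc(Cl)cc2)ccc1[C@@H](c1ccccc1)[C@@](O)(CCN(C)C)c1cccc2ccccc12` gives > 64 ug/mL, a limit of the assay.
Compound 2 `COc1nc(-c2cccc(F)c2)ccc1[C@@H](c1ccccc1)[C@@](O)(CCN(C)C)c1cccc2ccccc12` gives 62.8 ug/mL.
Compound 3 `COc1nc(-c2ccc(F)cc2)ccc1[C@@H](c1ccccc1)[C@@](O)(CCN(C)C)c1cccc2ccccc12` gives > 64 ug/mL, a limit of the assay.

In a toxicity assay on HeLa cells (Homo sapiens) for cytotoxicity (on this read-out lower numbers stand for higher toxicity in this test and higher numbers for lower toxicity in this test), compound 1 reaches only a limit of the assay, > 64 ug/mL. Compound 3 likewise stops at a limit, > 64 ug/mL. Compound 2 gives a number, 62.8 ug/mL. The steps of an at least 1.0-fold lower number from compound 1 to compound 2 (0.00 log units; that floor lies within the scatter) and an at least 1.0-fold higher number from compound 2 to compound 3 (0.00 log units; that floor lies within the scatter) both lie within the scatter, and a step that the two limits leave unreadable from compound 1 to compound 3 cannot be read because the limit of > 64 ug/mL in this assay, at which 2 of the 3 values shown sit, cuts off both values. Compound 4 `COc1nc(-c2ccc(C(F)(F)F)cc2)ccc1[C@@H](c1ccccc1)[C@@](O)(CCN(C)C)c1cccc2ccccc12` differs from compound 1 by trifluoromethyl in place of chloro on an aromatic carbon. The measured steps exchanged groups on this same ring and showed nothing beyond the scatter, so for compound 4 the expected step in this assay is a number no higher from compound 1 to compound 4 (the limit leaves the size open). Compound 4 is therefore estimated at 64 ug/mL, in a range from 35 ug/mL to 128 ug/mL.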

Compound 4, half-maximal cytotoxic concentration: > 64 ug/mL
Compound 4 gave a limit, no number (the forecaster's own chance of this, stated with the estimate: 60%); the middle value sits exactly at the limit.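

In this assay, trifluoromethyl, with 4 heavy atoms where chloro has 1, leaves compound 4 at the same limit of the assay as compound 1 and compound 3, so a larger group at this place still yields no number. Within the data shown here, the one readable step, an at least 1.0-fold higher number from compound 2 to compound 4 (0.00 log units; that floor lies within the scatter), shows no difference from the only compound with a number. The steps from compound 1 and from compound 3 to compound 4 cannot be read, because all three values are cut off: the limit of > 64 ug/mL in this assay, at which 3 of the 4 values shown sit.

As far as these compounds go, whether these three compounds truly differ stays open. So does whether an amine or a carboxylic acid at this place would bring a number under the limit.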